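The source may report more compounds than this note shows. Statements on the series, on what has been measured and on what is new or still open speak of the compounds shown alone.

Working notes on the series. For the measured compounds named here, compound 1 `COc1cccc(CSc2nnc([C@@H](C)c3ccc4cc(OC)ccc4c3)n2-c2ccc(F)cc2)c1` is the anchor: in a functional assay on LNCaP cells (Homo sapiens) for cytotoxicity, read by MTT assay (on this read-out higher numbers stand for weaker inhibition and lower numbers for stronger inhibition), compound 1 gives 14500 nM, the only value in this set read as a number. Compound 2 `COc1ccc2cc([C@H](C)c3nnc(SCc4ccc(C)cc4)n3-c3ccc(F)cc3)ccc2c1` carries 4-methylphenyl in place of 3-methoxyphenyl on a saturated chain carbon bound to a sulfur. In this assay compound 2 gives <= 400000 nM, which is a limit of the assay and not a number. Compound 3 `COc1ccc2cc([C@H](C)c3nnc(SCc4c(C)cc(C)cc4C)n3-c3cccc(Cl)c3)ccc2c1` is the other member. In this assay compound 3 gives <= 400000 nM, again a limit rather than a number. Going by the values given here, the single traceable step, a step that the limit leaves unreadable from compound 1 to compound 2, therefore has no readable size because of the limit of <= 400000 nM in this assay, at which 2 of the 3 values shown sit.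

Compound 4 `COc1ccc2cc([C@H](C)c3nnc(SCc4c(Cl)cccc4Cl)n3-c3ccc(F)cc3)ccc2c1` differs from compound 1 in one place: 2,6-dichlorophenyl in place of 3-methoxyphenyl on a saturated chain carbon bound to a sulfur. Among the compounds with values here, the only comparison that bears on this change is the one already noted, and it yields no magnitude; a second aryl change at the same carbon is the sole guide, and it leaves the direction open. Compound 4 is expected at 25000 nM. The range expected for compound 4 runs from 8000 nM to 120000 nM. The step this estimate implies, expected to stay within the usual scatter, is a 1.7-fold higher number from compound 1 to compound 4 (0.24 log units; within the scatter), with a real chance that the assay again returns only a limit.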

Compound 4, half-maximal inhibitory concentration: 12300 nM
Compound 4: the middle estimate sits 2.0-fold (0.31 log units) above what was measured, within the range that was stated.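

In this assay the aryl group on a saturated chain carbon bound to a sulfur now has its first readable step: 2,6-dichlorophenyl in place of 3-methoxyphenyl gives a 1.2-fold lower number from compound 1 to compound 4 (0.07 log units; within the scatter). This change swaps a group with one hydrogen-bond acceptor for one with none, and it replaces the methoxy oxygen with two chlorines, yet the step stays within the scatter, so across this one pair the read-out does not respond to the exchange. Compound 2 gives a limit of the assay rather than a number, so its steps to compound 1 and to compound 4 cannot be read: the limit of <= 400000 nM in this assay, at which 2 of the 4 values shown sit.

For the compounds shown here, with only one readable pair, the series gives no sign of what would move the read-out at this position beyond the scatter, and whether any other aryl group behaves like these two stays open. Also open, as far as these compounds go, is whether an amine or a carboxylic acid on this aryl ring, or a longer chain in place of the saturated chain carbon bound to a sulfur, would give a step larger than the one seen here.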